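Swapping Isopropyl for Cyclopropyl on a Sulfur

The source may hold more compounds than are shown below. What is called first, only, known or untested is meant among the compounds shown, and "the series" means these compounds.

Three measured compounds share one core and differ only in the group attached to the carbonyl carbon. In a functional assay on isolated protein for inhibition of Glucose-dependent insulinotropic receptor (Rattus norvegicus), read by HTRF and cAMP accumulation (on this read-out higher numbers stand for larger maximal responses and lower numbers for smaller maximal responses), compound 1 `Cc1nc(S(C)(=O)=O)ccc1Oc1ncnc(OC2CCN(C(=O)O[C@H](C)C(F)(F)F)CC2)c1F` gives 85%, compound 2 `Cc1nc(S(C)(=O)=O)ccc1Oc1ncnc(OC2CCN(C(=O)OC3(C(F)(F)F)CCC3)CC2)c1F` gives 82%, and compound 3 `Cc1nc(S(C)(=O)=O)ccc1Oc1ncnc(OC2CCN(C(=O)SC(C)C)CC2)c1F` gives 81%. The step of a number 3 percentage points lower from compound 1 to compound 2 (within the scatter) and the step of a number 4 percentage points lower from compound 1 to compound 3 (within the scatter) are both small, as is a number 1 percentage points lower from compound 2 to compound 3 (within the scatter). Compound 3 thus shows the smallest of the three numbers, but its gaps to compound 2 and to compound 1 are within the usual scatter, so the three values cannot be told apart.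

Compound 4 `Cc1nc(S(C)(=O)=O)ccc1Oc1ncnc(OC2CCN(C(=O)SC3CC3)CC2)c1F` has not yet been measured. Relative to compound 3 the change is cyclopropyl in place of isopropyl on a sulfur. Among the compounds with values here, no measured step swaps one group for another on this sulfur; the nearest information is that every change on the carbonyl carbon so far, whether an alkoxy or a sulfanyl group of various sizes, left the response unchanged beyond the scatter. A change as small as isopropyl to cyclopropyl on the same sulfur is therefore expected to give no step beyond the scatter, that is a number 1 percentage points lower from compound 3 to compound 4 (within the scatter). Compound 4 is estimated at 80%, with a range from 70% to 90%.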

Compound 4, largest response reached (reported as efficacy), in percent of the reference or control that the assay uses: 80%
The estimate for compound 4 equals the measured number at the digits printed; the range from low to high includes it.
By their numbers in this assay, from the lowest: compounds 4, 3, 2 and 1 (each within the scatter of the next).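

In this assay, the cyclopropyl group brings a three-membered ring onto a sulfur where earlier compounds carried only the open-chain isopropyl group, and this gives a number 1 percentage points lower from compound 3 to compound 4 (within the scatter), the first step shown that changes the group on this sulfur while the sulfur itself stays in place. The comparison with the two compounds that have an oxygen on the carbonyl carbon gives a number 2 percentage points lower from compound 2 to compound 4 (within the scatter) and a number 5 percentage points lower from compound 1 to compound 4 (within the scatter), so the cyclopropylsulfanyl group also cannot be told apart from either of those larger groups on this read-out, and all four compounds now sit within the scatter of their neighbours in the order of values. Nothing measured here offers an explanation for this flat response.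

The compounds shown leave open whether a phenyl ring or a longer chain such as hexyl on this sulfur would still keep the response within the scatter of these four values. They also leave open what an amine on the carbonyl carbon, in place of both the oxygen and the sulfur groups, would do to the maximal response.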